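The source may hold more compounds than are shown below. What is called first, only, known or untested is meant among the compounds shown, and "the series" means these compounds.

Of the compounds shown here, three have been measured in a functional assay on MCF7 cells (Homo sapiens) for inhibition, read by MTT assay, with a stated time of 48 h, tested at 15 ug/mL; on this read-out higher numbers stand for more inhibition of growth at the one concentration tested and lower numbers for less inhibition of growth. Compound 1 `COc1cc2c(c(OC)c1)OCN(c1ccc3oc(-c4ccccc4)cc(=O)c3c1)C2` gives 60%, compound 3 `O=c1cc(-c2ccccc2)oc2ccc(N3COc4c(cccc4[N+](=O)[O-])C3)cc12` gives 55.9%, and compound 2 `O=c1cc(-c2ccccc2)oc2cc(N3COc4ccccc4C3)ccc12` gives 3.89%, the lowest of the three numbers: compound 3 sits closest, beyond the scatter, and compound 1 furthest, also beyond the scatter. Compound 4 `O=c1cc(-c2ccccc2)oc2cc(N3COc4c(Br)cccc4C3)ccc12` has not yet been measured. It differs from compound 2 in one place (bromo in place of hydrogen on an aromatic carbon). Going by the values given here, no single-point step between measured compounds exists to calibrate this change, so the size of the step is open; the author expects in this assay a rise beyond the scatter from compound 2 to compound 4, a number 28.1 percentage points higher from compound 2 to compound 4 (beyond the scatter), with wide uncertainty. The estimate for compound 4 is 32%, ranging from 8% to 62%.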

Compound 4, percent growth inhibition at one concentration: 5.64%
Estimate against measurement, compound 4: 26.4 percentage points above; measured number below the stated range.
By their numbers in this assay, from the lowest: compounds 2 and 4 (each within the scatter of the next); then compounds 3 and 1 (each within the scatter of the next).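

In this assay bromo in place of hydrogen on an aromatic carbon, ortho to a fused ring, gives a number 1.8 percentage points higher from compound 2 to compound 4 (within the scatter) and so leaves the read-out where compound 2 had it. Going by these compounds alone, this is the first single-place step available, and it shows that this change at this position does not raise the number beyond the scatter. No measurement shown here accounts for this result. Going by these compounds, whether fluoro, an amine or a carboxylic acid on this carbon would behave the same stays open. So does the effect of bromo on the other carbons of that ring.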